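Dropping the Chloro Group: What Compound 3 Should Show

The compounds below may be only part of what the source reports. "The series", "measured", "known", "first", "only" and "open" are said of these compounds alone.

Compound 1 `COc1c(Br)cccc1C(=O)Nc1ccccc1`: > 100000 nM
Compound 2 `O=C(Nc1cccc(Cl)c1)c1cccc(Br)c1O`: > 100000 nM

In an assay on isolated protein for inhibition of thiosulfate sulfurtransferase (Homo sapiens), with a stated time of 60 min, in the absence of a further agent (a lower number here means a stronger inhibitor, a higher number a weaker inhibitor), compound 2 gives > 100000 nM, which is a limit of the assay rather than a number. In this assay compound 1 likewise gives > 100000 nM, again a limit. Both measured values therefore sit at the same point: the limit of > 100000 nM in this assay, at which 2 of the 2 values shown sit. Compound 3 `O=C(Nc1ccccc1)c1cccc(Br)c1O` differs from compound 2 by hydrogen in place of chloro on an aromatic carbon. Among the compounds with values here, no measured step between these compounds exists, so no shift beyond the scatter is expected. Compound 3 is estimated at 150000 nM, with a range from 50000 nM to 500000 nM, most likely reported only as a limit, and the expected step that the limit leaves unreadable from compound 2 to compound 3 is essentially none.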

Compound 3, half-maximal inhibitory concentration: > 100000 nM
Compound 3: no number, only a limit; the forecaster's own chance of this, stated with the estimate: 85%; the middle value lies beyond the limit too.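

In this assay, within the data shown here, compound 3 gives > 100000 nM, a limit, so no step from compound 1 or compound 2 to compound 3 can be read. The compounds shown leave open which change to the shared core, if any, would give a readable value: the limit of > 100000 nM in this assay, at which 3 of the 3 values shown sit.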